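Pyridin-4-yl in place of 4-chlorophenyl: compound 4

The compounds below may be only part of what the source reports. "The series", "measured", "known", "first", "only" and "open" are said of these compounds alone.

Measured compounds:
- compound 1 `Cc1c(-c2cc(Cl)cc(Cl)c2)c(C(=O)O)nn1-c1nc(-c2cc(Cl)ccc2F)c(SC(C)C)s1`: in a functional assay on BJAB cells (Homo sapiens) for antiproliferative activity, with a stated time of 4 days (on this read-out lower numbers stand for an effect already at smaller amounts and higher numbers for an effect only at larger amounts of compound), compound 1 gives 4800 nM
- compound 2 `Cc1nn(-c2nc(-c3ccc(Cl)c(Cl)c3)c(SC(C)C)s2)c(C(=O)O)c1-c1ccc(Cl)cc1`: in this assay compound 2 gives 2500 nM
- compound 3 `Cc1oncc1-c1nc(-n2nc(C(=O)O)c(-c3cc(Cl)cc(Cl)c3)c2C)sc1SC(C)C`: in this assay compound 3 gives only a limit, > 44000 nM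

Compound 2 holds the lowest of the two numbers; compound 1 is within the scatter of it, so no order between the two can be stated. Among the compounds with values here, the one measured step runs elsewhere: an at least 9.1-fold higher number from compound 1 to compound 3 (0.96 log units; beyond the scatter), ending at the limit of > 44000 nM in this assay, at which 1 of the 3 values shown sits.

Compound 4 `Cc1nn(-c2nc(-c3ccc(Cl)c(Cl)c3)c(SC(C)C)s2)c(C(=O)O)c1-c1ccncc1` differs from compound 2 by pyridin-4-yl in place of 4-chlorophenyl on an aromatic carbon. Within the data shown here, no measured step touches this position, so the step from compound 2 to compound 4 has no direct precedent here; the single step that exists concerns another part of the shared core, and it shows that changing an aryl group on the core can cost much in this assay. Some loss is therefore expected rather than none, worded as an expectation only: a 3.2-fold higher number from compound 2 to compound 4 (0.51 log units; beyond the scatter). Compound 4 is estimated at 8000 nM, within 2500 nM to 40000 nM.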

Compound 4, half-maximal effective concentration: 5900 nM
The estimate for compound 4 lay 1.4-fold (0.13 log units) above the measured number; measured number inside the range.
By their numbers in this assay, from the lowest: compounds 2, 1 and 4 (each within the scatter of the next, the first and the last beyond it). At a limit, above all of these: compound 3.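

Within the data shown here, the step of a 2.4-fold higher number from compound 2 to compound 4 (0.37 log units; beyond the scatter) in this assay gives the first reading at this place, an aromatic carbon of a five-membered aromatic ring with 2 nitrogen. Replacing 4-chlorophenyl with pyridin-4-yl has a modest but real cost here, and compound 4 still gives a measured number, so the 4-chlorophenyl group is not essential for a reading in this assay. The only value at a limit remains that of compound 3, which is a limit and not a number: the limit of > 44000 nM in this assay, at which 1 of the 4 values shown sits.

This single step changes two things at once, the loss of the chlorine and the entry of the ring nitrogen, and a plain phenyl would be needed to separate them. As far as these compounds go, it also remains open how a non-aromatic amine such as piperidin-4-yl, or a longer chain, would fare at this place.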